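Moving a Chlorine Substituent: Compound 1 to Compound 4

A few compounds are considered here, and "the series" means these few. Any claim that something is new, unique, unknown or untested is made for them only; others in the source may bear on it.

Compound 1, `Cc1nc(-c2ccc(Cl)cc2)sc1C(=O)CSc1nc(-c2cccc(Cl)c2)c(C#N)c(=O)[nH]1`: 95.2%
Compound 2, `Cc1nc(-c2ccccc2)sc1C(=O)CSc1nc(N)c(C#N)c(-c2ccc(Cl)cc2)n1`: 58.8%
Compound 3, `Cc1nc(-c2ccccc2)sc1C(=O)CSc1nc(-c2cccc(Cl)c2)c(C#N)c(=O)[nH]1`: 83.7%

In a functional assay on U-87MG ATCC cells for antiproliferative activity against U-87 MG (Homo sapiens), read by MTT assay, with a stated time of 48 h, tested at 10 uM (a lower number here means a stronger effect, a higher number a weaker effect of the compound at the concentration tested), compound 1 gives 95.2%, the highest of the three numbers and thus the weakest effect. Its nearest neighbour is compound 3, reached by a number 11.5 percentage points lower from compound 1 to compound 3 (beyond the scatter); compound 2 lies furthest from it. Compound 4, `Cc1nc(-c2ccc(Cl)cc2)sc1C(=O)CSc1nc(-c2ccc(Cl)cc2)c(C#N)c(=O)[nH]1`, differs from compound 1 in one place: 4-chlorophenyl in place of 3-chlorophenyl on an aromatic carbon. Going by the values given here, the only measured single step, a number 11.5 percentage points lower from compound 1 to compound 3 (beyond the scatter), removes a chlorine from the other aryl ring and does not concern the ring changed here, so no measured step bears directly on this change. A step of no more than the usual scatter is therefore expected, a number 4.2 percentage points lower from compound 1 to compound 4 (within the scatter). Compound 4 is estimated at 91%, between 74% and 100%.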

Compound 4, a percentage reported as activity, at one concentration (the size of the read-out at that concentration, not a potency): 98.4%
Compound 4: middle estimate off by 7.4 percentage points, on the low side; the range from low to high includes it.
By their numbers in this assay, from the lowest: compound 2; then compound 3; then compounds 1 and 4 (each within the scatter of the next).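

In this assay the swap of 3-chlorophenyl for 4-chlorophenyl gives a number 3.2 percentage points higher from compound 1 to compound 4 (within the scatter) and so does not separate the two chlorine placements on this ring. Going by these compounds alone, this is the only measured step on this ring, and it shows that the read-out at this place tolerates the chlorine's move without a change beyond the scatter. Nothing available here accounts for this result.

Going by these compounds, whether a methoxy group or an amine in place of the chlorine on this ring would lower the number stays open. So does whether the same move would matter with no chlorine on the other aryl ring.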